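This account rests on a few compounds, and the source may have more. Where it says the series, first, only, none or still open, it means among the compounds named here.

Working notes on the series. The three measured compounds share one core and differ only in the group on the six-membered aromatic ring. Compound 1 `O=C(CCC(=O)c1ccccc1)Nc1nc2ccc(Cl)cc2s1` gives 300 mg/kg in a functional assay on the whole organism with Mus musculus as the target, with a stated time of 4 h; a higher number here means that more compound is needed for the effect, a lower number that less compound is needed. Compound 2 `Cc1ccc2nc(NC(=O)CCC(=O)c3ccccc3)sc2c1` gives 300 mg/kg in this assay, and no change at the digits printed from compound 1 to compound 2 (within the scatter). Compound 3 `COc1ccc2nc(NC(=O)CCC(=O)c3ccccc3)sc2c1` gives 100 mg/kg in this assay, the lowest of the three numbers: a 3.0-fold lower number from compound 1 to compound 3 (0.48 log units; beyond the scatter), and a 3.0-fold lower number from compound 2 to compound 3 (0.48 log units; beyond the scatter).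

Compound 4 `CC(=O)c1ccc2nc(NC(=O)CCC(=O)c3ccccc3)sc2c1` has not been measured. The change from compound 3 is acetyl in place of methoxy on an aromatic carbon. Among the compounds with values here, no measured step involves acetyl, so nothing bears on this change directly. What the measured steps show is that exchanging the group at this position gives either no change, as in no change at the digits printed from compound 1 to compound 2 (within the scatter), or a modest move, as in a 3.0-fold lower number from compound 1 to compound 3 (0.48 log units; beyond the scatter). The direction for acetyl cannot be read from them; since compound 3 holds the lowest number, the expected step of a 2.0-fold higher number from compound 3 to compound 4 (0.30 log units; within the scatter) is a modest rise, with wide uncertainty. Compound 4 is therefore expected to give 200 mg/kg in this assay, within 100 mg/kg to 600 mg/kg.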

Compound 4, minimum effective dose: 300 mg/kg
The estimate for compound 4 lay 1.5-fold (0.18 log units) below the measured number, within the range that was stated.
By their numbers in this assay, from the lowest: compound 3; then compounds 1, 2 and 4 (each within the scatter of the next).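

Acetyl is the first group here that shares neither a position in the series with methoxy nor its low number, with a 3.0-fold higher number from compound 3 to compound 4 (0.48 log units; beyond the scatter) in this assay. With no change at the digits printed from compound 2 to compound 4 (within the scatter) and no change at the digits printed from compound 1 to compound 4 (within the scatter), acetyl cannot be told apart from methyl or chloro at this position, so among the four groups only methoxy stands apart, and its steps to all three lie beyond the scatter. No measurement shown here bears on what sets methoxy apart from the other three groups.

The compounds shown leave open whether an amine, a carboxylic acid or ethoxy at this position would fall with methoxy or with the other three groups. They also leave open whether methoxy would give the same step on another carbon of the six-membered aromatic ring, or with a longer chain in the shared core.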